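Aryl ether variation on the shared core

A few compounds are considered here, and "the series" means these few. Any claim that something is new, unique, unknown or untested is made for them only; others in the source may bear on it.

Measured so far in a functional assay for agonist activity at Glucose-dependent insulinotropic receptor (Mus musculus), read by HTRF and cAMP accumulation, with a stated time of 45 min; a lower number here means that less compound is needed, a higher number that more compound is needed for the effect:
compound 1 `C[C@@H]1CN(C(=O)OC(C)(C)C)CCN1c1ncc(OCc2ccc(C#N)cc2)cn1` gives 148 nM
compound 2 `C[C@@H]1CN(C(=O)OC(C)(C)C)CCN1c1ncc(OCc2ccc(-n3cnnn3)cc2)cn1` gives 33 nM

For the measured compounds named here, compound 2 holds the lowest number of the two; its nearest neighbour is compound 1, and the single step recorded, a 4.5-fold lower number from compound 1 to compound 2 (0.65 log units; beyond the scatter), is beyond the scatter. Compound 3 `Cc1cnccc1COc1cnc(N2CCN(C(=O)OC(C)(C)C)C[C@H]2C)nc1` is the next member. Against compound 2 the change is 3-methylpyridin-4-yl in place of 4-(1H-tetrazol-1-yl)phenyl on a saturated chain carbon bound to an oxygen on an aromatic ring. Going by the values given here, no measured step bears directly on this change: the one step at hand, from compound 1 to compound 2, concerns only the group on the phenyl ring, whereas here the whole phenyl ring with its tetrazole leaves and a smaller ring with a single hetero atom enters. The step from compound 1 to compound 2 shows that this part of the molecule matters to the read-out, so a shift beyond the scatter in either direction is possible. With the tetrazole gone and the remaining reference compound 1 standing higher, the expected result for compound 3 is a higher number than compound 2, estimated as a 3.6-fold higher number from compound 2 to compound 3 (0.56 log units; beyond the scatter). For compound 3 the estimate is 120 nM, with a range from 30 nM to 500 nM.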

Compound 3, half-maximal effective concentration: 236 nM
For compound 3 the middle estimate is 2.0-fold (0.29 log units) below the measured one; the measured number falls inside the stated range.
By their numbers in this assay, from the lowest: compound 2; then compounds 1 and 3 (each within the scatter of the next).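

In this assay, this position now has a change of the whole ring behind it and not only of the group on the phenyl ring: 3-methylpyridin-4-yl in place of 4-(1H-tetrazol-1-yl)phenyl gives a 7.2-fold higher number from compound 2 to compound 3 (0.85 log units; beyond the scatter) on the same shared core. Against 4-cyanophenyl, the same 3-methylpyridin-4-yl gives a 1.6-fold higher number from compound 1 to compound 3 (0.20 log units; within the scatter), so these two groups cannot be ordered, and among the three compounds only the one carrying 4-(1H-tetrazol-1-yl)phenyl separates from the others. Nothing measured here explains why the number moves with these groups at this position.

The compounds shown leave open whether the result for compound 3 belongs to the ring nitrogen or to the methyl group, as no pair separates the two, and whether the gain seen with the tetrazole needs the phenyl ring under it. Also open, as far as these compounds go, is how a carboxylic acid or a methylsulfonyl group on that phenyl ring would stand against the tetrazole and the nitrile.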